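Will compound 4 remain as well tolerated?

The compounds below may be only part of what the source reports. "The series", "measured", "known", "first", "only" and "open" are said of these compounds alone.

In an ADME assay on BHK cells (Mesocricetus auratus) for cytotoxicity, read by MTT assay, with a stated time of 96 h (a higher number here means that more compound is tolerated, a lower number that less compound is tolerated), compound 1 (`CCNC(=S)Nc1cccc(C(F)(F)F)c1`) gives > 100000 nM, a limit of the assay and not a number. Compound 2 (`CC(=O)NC(=S)Nc1cccc(C(F)(F)F)c1`) gives > 100000 nM, again only a limit. Compound 3 (`C=C(C)CNC(=S)Nc1cccc(C(F)(F)F)c1`) gives > 100000 nM, also only a limit. Compound 3 therefore stands at the limit of > 100000 nM in this assay, at which 3 of the 3 values shown sit.

Compound 4 (`Fc1ccccc1NC(=S)Nc1cccc(C(F)(F)F)c1`) carries 2-fluorophenyl in place of 2-methylprop-2-en-1-yl on an amide-type nitrogen. Among the compounds with values here, three measured steps bear on this change: a step that the two limits leave unreadable from compound 1 to compound 2, a step that the two limits leave unreadable from compound 1 to compound 3 and a step that the two limits leave unreadable from compound 2 to compound 3. None of them offers a size to carry over, and none brings in an aromatic ring. The limit of compound 3, > 100000 nM, gives no number to start from, so only a modest fall in the tolerated concentration is expected, and another limit remains quite possible. The expected change is an at least 1.4-fold lower number from compound 3 to compound 4 (0.15 log units; that floor lies within the scatter). For compound 4 the estimated value is 70000 nM, with an expected range of 20000 nM to 200000 nM.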

Compound 4, half-maximal cytotoxic concentration: 54000 nM
Compound 4: middle estimate off by 1.3-fold (0.11 log units), on the high side; the range from low to high includes it.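

In this assay, within the data shown here, compound 4 gives 54000 nM, the first true number, so 2-fluorophenyl on an amide-type nitrogen brings the reading within what the assay can report. Compound 1, compound 2 and compound 3 each give only a limit of the assay, so the steps among them cannot be read: the limit of > 100000 nM in this assay, at which 3 of the 4 values shown sit. Set against those limits, the change reads as an at least 1.8-fold lower number from compound 3 to compound 4 (0.26 log units; that floor lies within the scatter), as an at least 1.8-fold lower number from compound 2 to compound 4 (0.26 log units; that floor lies within the scatter) and as an at least 1.8-fold lower number from compound 1 to compound 4 (0.26 log units; that floor lies within the scatter), and each of these is a floor whose true size stays unknown.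

With only one aromatic group shown, the compounds cannot separate the part played by the ring from that of its fluorine, which plain phenyl would address. Going by these compounds, how a longer chain or a carboxylic acid at this nitrogen would read also remains open.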